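A few compounds are considered here, and "the series" means these few. Any claim that something is new, unique, unknown or untested is made for them only; others in the source may bear on it.

Three compounds share one core and differ only in the group carried on a saturated chain carbon bound to a saturated ring carbon. Compound 1 `CN(CCC#N)C[C@H]1CN(c2ccc(-n3cc(-c4ccccn4)cn3)c(F)c2)C(=O)O1` carries a (2-cyanoethyl)(methyl)amino group there. In an ADME assay on HEK293-A cells (Homo sapiens) for cytotoxicity, read by MTT assay, with a stated time of 48 h (on this read-out higher numbers stand for weaker inhibition and lower numbers for stronger inhibition), compound 1 gives > 400 ug/mL, which is a limit of the assay rather than a number. Compound 2 `CN1CCN(C[C@H]2CN(c3ccc(-n4cc(-c5ccccn5)cn4)c(F)c3)C(=O)O2)CC1` carries a 4-methylpiperazin-1-yl group, and in this assay compound 2 gives 70 ug/mL. Compound 3 `O=C1O[C@@H](CN2CCCCC2)CN1c1ccc(-n2cc(-c3ccccn3)cn2)c(F)c1` carries a piperidin-1-yl group. In this assay compound 3 gives > 400 ug/mL, again a limit of the assay. So compound 3 stands at the limit of > 400 ug/mL in this assay, at which 2 of the 3 values shown sit. Of the measured steps, an at least 5.7-fold higher number from compound 2 to compound 3 (0.75 log units; beyond the scatter) is readable, whereas a step that the two limits leave unreadable from compound 1 to compound 3. Compound 4 `O=C1CNC(=O)N1C[C@H]1CN(c2ccc(-n3cc(-c4ccccn4)cn3)c(F)c2)C(=O)O1` is the next step: 2,5-dioxoimidazolidin-1-yl in place of piperidin-1-yl on a saturated chain carbon bound to a saturated ring carbon. Among the measured compounds shown here, no measured step involves this group, and the two limits give no scale for such a change. Because compound 3 sits at the limit of > 400 ug/mL in this assay, at which 2 of the 3 values shown sit, compound 4 is expected to remain near that limit, with a number no higher from compound 3 to compound 4 (the limit leaves the size open). The estimate for compound 4 is 400 ug/mL, between 150 ug/mL and 800 ug/mL.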

Compound 4, half-maximal inhibitory concentration: > 400 ug/mL
Compound 4: no number, only a limit (the forecaster's own chance of this, stated with the estimate: 75%); the middle value lies on the limit itself.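

In this assay compound 4 gives > 400 ug/mL, which is a limit of the assay and not a number. Set against the 4-methylpiperazin-1-yl group, the result reads as an at least 5.7-fold higher number from compound 2 to compound 4 (0.75 log units; beyond the scatter), so a second ring group on this saturated chain carbon now parts from compound 2, and this one carries a hydrogen-bond donor that piperidin-1-yl lacks. The steps from compound 1 and compound 3 to compound 4 cannot be read, and compound 2 is still the only one with a number: the limit of > 400 ug/mL in this assay, at which 3 of the 4 values shown sit.

As far as these compounds go, how far the true values of compound 1, compound 3 and compound 4 lie past their limits stays unknown, so these three groups cannot be ranked against one another. The compounds shown also do not tell whether the methyl or the second ring nitrogen of compound 2 goes with its lower number, a question on which a plain piperazin-1-yl or a morpholin-4-yl group at this place would bear.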